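Replacing 4-(dimethylamino)phenyl with pyridin-2-yl on the shared core

The compounds below may be only part of what the source reports. "The series", "measured", "known", "first", "only" and "open" are said of these compounds alone.

Compound 1 `Cc1ccc(-c2cc(C(=O)N3CCC4(CC3)CC(=O)c3nn(C(C)(C)C)cc3O4)c3ccccc3n2)cc1` gives 5300 nM
Compound 2 `CN(C)c1ccc(-c2cc(C(=O)N3CCC4(CC3)CC(=O)c3nn(C(C)(C)C)cc3O4)c3ccccc3n2)cc1` gives 1150 nM
Compound 3 `CC(C)(C)n1cc2c(n1)C(=O)CC1(CCN(C(=O)c3cc(-c4ccccn4)nc4ccccc34)CC1)O2` has no value yet

Going by the values given here, in a functional assay on A549 cells (Homo sapiens) for inhibition, read by MTT assay, with a stated time of 72 h (on this read-out higher numbers stand for weaker inhibition and lower numbers for stronger inhibition), compound 2 stands at 1150 nM and holds the lower of the two numbers so far. Compound 3 carries pyridin-2-yl in place of 4-(dimethylamino)phenyl on an aromatic carbon, next to the ring nitrogen pyridin-2-yl in place of 4-(dimethylamino)phenyl on an aromatic carbon and so has no dimethylamino group. Among the compounds with values here, only one measured step bears on this change. It is a 4.6-fold lower number from compound 1 to compound 2 (0.66 log units; beyond the scatter) with dimethylamino in place of methyl on an aromatic carbon, at the same aryl group that compound 3 gives up. Within the data shown here, compound 1, the only measured compound without dimethylamino, sits at 5300 nM in this assay and suggests that losing this group costs activity. Among the measured compounds shown here, no measured compound carries a pyridine at this place, so the size of the change remains uncertain. An estimated step of a 3.0-fold higher number from compound 2 to compound 3 (0.48 log units; beyond the scatter) is expected, modest in size and towards a higher number. For compound 3 the expected value is 3500 nM with an estimated range from 1300 nM to 10000 nM in this read-out.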

Compound 3, half-maximal inhibitory concentration: 7720 nM
Estimate against measurement, compound 3: 2.2-fold (0.34 log units) below; the measured number falls inside the stated range.
By their numbers in this assay, from the lowest: compound 2; then compounds 1 and 3 (each within the scatter of the next).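

In this assay, the change to pyridin-2-yl gives a 6.7-fold higher number from compound 2 to compound 3 (0.83 log units; beyond the scatter), which shows that the lower number of compound 2 does not hold when 4-(dimethylamino)phenyl gives way to this smaller aromatic ring, even though both groups count one hydrogen-bond acceptor. Going by these compounds alone, the comparison that the earlier compounds could not offer is a 1.5-fold higher number from compound 1 to compound 3 (0.16 log units; within the scatter), so pyridin-2-yl and 4-methylphenyl cannot be told apart at this position, and with steps beyond the scatter to both others, 4-(dimethylamino)phenyl alone stands apart among the three groups, with compound 2 the most active of the three compounds in this read-out. No measurement shown accounts for these differences.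

The compounds shown leave open whether the lower number of compound 2 is tied to the dimethylamino group itself or would also appear with another group in its place on the phenyl ring, such as a primary amine, a methoxy group or a morpholine. They also leave open whether a dimethylamino group carried on the pyridine ring of compound 3 would bring its number down.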